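A few compounds are considered here, and "the series" means these few. Any claim that something is new, unique, unknown or untested is made for them only; others in the source may bear on it.

Of the compounds shown here, three built on one shared core have been measured in a functional assay on Caco-2 cells (Homo sapiens) for cytotoxicity, read by cell counting, with a stated time of 48 h; on this read-out lower numbers stand for stronger inhibition and higher numbers for weaker inhibition. Compound 1 `Cc1ccc(-n2cc(COc3cccc4cnc(Nc5cccc(Cl)c5)nc34)nn2)c([N+](=O)[O-])c1` gives 37000 nM in this assay. Compound 2 `Clc1ccc(-n2cc(COc3cccc4cnc(Nc5cccc(Cl)c5)nc34)nn2)cc1` gives 24000 nM, and a 1.5-fold lower number from compound 1 to compound 2 (0.19 log units; within the scatter). Compound 3 `Clc1cccc(Nc2ncc3cccc(OCc4cn(Cc5c(Cl)cccc5Cl)nn4)c3n2)c1` gives 9000 nM, the lowest of the three numbers; a 4.1-fold lower number from compound 1 to compound 3 (0.61 log units; beyond the scatter) and a 2.7-fold lower number from compound 2 to compound 3 (0.43 log units; beyond the scatter), so compound 3 stands clearly apart from both of the others. Compound 4 `Clc1cccc(Nc2ncc3cccc(OCc4cn(-c5cc(Cl)cc(Cl)c5)nn4)c3n2)c1` has not yet been measured. It differs from compound 3 in a single place: 3,5-dichlorophenyl in place of 2,6-dichlorobenzyl on an aromatic nitrogen. Both measured steps that bear on this change went in the opposite direction, replacing an aromatic ring sitting directly on the ring nitrogen with the 2,6-dichlorobenzyl group, and each time the number fell modestly. The change to compound 4 puts a ring directly on that nitrogen again, though the pattern of chlorines on it is not the same as in compound 2, so the match is only partial. A modest rise in the number in this assay is therefore expected, roughly the reverse of a 2.7-fold lower number from compound 2 to compound 3 (0.43 log units; beyond the scatter). The step of a 2.0-fold higher number from compound 3 to compound 4 (0.30 log units; within the scatter) is the expected outcome. Compound 4 is estimated at 18000 nM, with a range from 8000 nM to 40000 nM.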

Compound 4, half-maximal inhibitory concentration: 8000 nM
Beside the measured number, compound 4's estimate is 2.3-fold (0.35 log units) above it, and the stated range covers the measured number.
By their numbers in this assay, from the lowest: compounds 4 and 3 (each within the scatter of the next); then compounds 2 and 1 (each within the scatter of the next).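

In this assay, going by these compounds alone, a ring set directly on the aromatic nitrogen does not by itself hold the number up: 3,5-dichlorophenyl in place of 2,6-dichlorobenzyl gives a 1.1-fold lower number from compound 3 to compound 4 (0.05 log units; within the scatter) and so leaves the two groups indistinguishable here, even though the earlier steps had favoured the benzyl group over the directly attached rings. What now matters is what the directly attached ring carries, with 3,5-dichlorophenyl in place of 4-chlorophenyl giving a 3.0-fold lower number from compound 2 to compound 4 (0.48 log units; beyond the scatter) and 3,5-dichlorophenyl in place of 4-methyl-2-nitrophenyl giving a 4.6-fold lower number from compound 1 to compound 4 (0.67 log units; beyond the scatter) as steps beyond the scatter. No measurement at hand explains why these groups differ or match.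

Every group shown on this nitrogen contains a substituted aromatic ring, so it remains open how the number would respond to something quite different there, such as a plain alkyl chain, an amine or a carboxylic acid. As far as these compounds go, it also remains open whether the number of chlorines or their placement accounts for the gap to 4-chlorophenyl, a question that a 3-chlorophenyl or 3,5-dichlorobenzyl group on the same nitrogen could help to settle.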